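The source may report more compounds than this note shows. Statements on the series, on what has been measured and on what is new or still open speak of the compounds shown alone.

Of the compounds shown here, three built on a shared core have been measured so far in a physicochemical assay for lipophilicity, measured as octanol-water partition; on this read-out lower numbers stand for lower lipophilicity and higher numbers for higher lipophilicity. Compound 1 `C/C(=N\NC(=O)COc1cccc2ccccc12)c1cccc([N+](=O)[O-])c1` gives 3.37, and compound 2 `COc1ccc(/C=N/NC(=O)COc2cccc3ccccc23)cc1O` gives 3.48, so these two lie within the scatter of each other. Compound 3 `O=C(COc1cccc2ccccc12)N/N=C/c1ccc(Br)cc1` gives 4.81, the highest of the three numbers, and its distance from each of the other two lies beyond the scatter.

The account now turns to compound 4 `O=C(COc1cccc2ccccc12)N/N=C/c1ccc(F)cc1`, which differs from compound 3 in one place: fluoro in place of bromo on an aromatic carbon. It carries fluoro in place of bromo on an aromatic carbon, para to a large group. Going by the values given here, no measured pair in this small set differs in one place, so the data offer no direct precedent, and the expectation rests on the structural change alone. In this assay a fall beyond the scatter is expected, estimated as a number 0.71 log units lower from compound 3 to compound 4 (beyond the scatter). Compound 4 is expected at 4.1, with an estimated range of 3.65 to 4.55.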

Compound 4, partition coefficient: 4.16
Estimate against measurement, compound 4: 0.06 log units below; the range from low to high includes it.
By their numbers in this assay, from the lowest: compounds 1 and 2 (each within the scatter of the next); then compound 4; then compound 3.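

Going by these compounds alone, this is the first pair in the set that differs in one place, so the 4-bromophenyl to 4-fluorophenyl change can now be read directly. In this assay, fluoro in place of bromo on an aromatic carbon, para to a large group, gives a number 0.65 log units lower from compound 3 to compound 4 (beyond the scatter) and so moves the read-out even though the rest of the structure stays the same. The compounds shown offer no measurement that explains the size of this step.

Where chloro, methyl, an amine or a carboxylic acid would fall at this same place remains open, as this single pair sets only two points on the scale. Also open, from the compounds shown here alone, is whether the same exchange would give a step of similar size at another place on this ring or on a different core.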